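The compounds below may be only part of what the source reports. "The series", "measured", "known", "first", "only" and "open" are said of these compounds alone.

Of the compounds shown here, two sharing one core have been tested in a functional assay on HCT-116 cells (Homo sapiens) for cytotoxicity, read by MTT assay, with a stated time of 72 h; a lower number here means a stronger inhibitor, a higher number a weaker inhibitor. Compound 1 `N[C@H]1CC[C@H](NC(=O)c2nc(Br)c3cccnc3c2NCc2ccc(F)cc2)CC1` gives 6400 nM in this assay. Compound 2 `N[C@H]1CC[C@H](Nc2c(C(=O)NCc3ccc(Cl)cc3Cl)nc(Br)c3cccnc23)CC1` gives 6000 nM in this assay. These two numbers lie within the usual scatter of each other, so compound 2 cannot be set apart from compound 1: the two compounds behave alike in this assay.

The next compound, compound 3 `N[C@H]1CC[C@H](Nc2c(C(=O)Nc3ccccc3)nc(Br)c3cccnc23)CC1`, is compound 2 with a smaller group on the amide nitrogen: phenyl in place of 2,4-dichlorobenzyl on an amide-type nitrogen. For the measured compounds named here, no measured pair in this set shows what such a swap does, so there is no direct guide to the size or direction of the step. Compound 1 with 6400 nM and compound 2 with 6000 nM carry quite different groups at that end yet give matching numbers, which hints that the group there is not decisive. A step of modest size is therefore expected from compound 2 to compound 3, a 1.3-fold higher number from compound 2 to compound 3 (0.12 log units; within the scatter), most likely a slight weakening that stays near the scatter. Compound 3 is estimated at 8000 nM in this assay, within a range from 2500 nM to 25000 nM.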

Compound 3, half-maximal inhibitory concentration: 2000 nM
The estimate for compound 3 lay 4.0-fold (0.60 log units) above the measured number, and the stated range ends above it.
By their numbers in this assay, from the lowest: compound 3; then compounds 2 and 1 (each within the scatter of the next).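

In this assay, for the compounds shown here, replacing 2,4-dichlorobenzyl with phenyl on the amide-type nitrogen gives a 3.0-fold lower number from compound 2 to compound 3 (0.48 log units; beyond the scatter), the first clear evidence in this set that the group at this position can change the result, with the smaller phenyl giving the stronger inhibitor. Compounds 1 and 2 could not show this, since they differ in more than one place and so give no clean reading of this nitrogen, whereas compound 2 and compound 3 differ only in this group. The dichlorobenzyl group is therefore not needed for activity in this cell assay, and nothing available explains why its removal lowers the number.

The swap removes the chlorine atoms and the benzyl carbon together, so these compounds cannot tell which of the two changes accounts for the step. A plain benzyl or a chlorophenyl group on this nitrogen would separate those two changes, while a methyl or a cyclohexyl group would test whether an aromatic ring is needed here at all.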